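Urea nitrogen enlarged: dimethylamino to pyrrolidinyl

A few compounds are considered here, and "the series" means these few. Any claim that something is new, unique, unknown or untested is made for them only; others in the source may bear on it.

Compound 3 `CN(C)C(=O)N(Cc1ccccc1-c1ccccc1)[C@H]1CCNC1` is a urea on the shared core. In an assay on HEK293 cells for inhibition of sodium-dependent dopamine transporter (Homo sapiens) (a lower number here means a stronger inhibitor, a higher number a weaker inhibitor), compound 3 gives 2970 nM. For the measured compounds named here, the only other number in this assay comes from the sulfonamide compound 1 `CC(C)S(=O)(=O)N(Cc1ccccc1-c1ccccc1)[C@H]1CCNC1`, which in this assay gives 2700 nM; the two numbers are indistinguishable within the scatter, as the step of a 1.1-fold higher number from compound 1 to compound 3 (0.04 log units; within the scatter) shows. The amide compound 2 `CC(C)CC(=O)N(Cc1ccccc1-c1ccccc1)[C@H]1CCNC1` in this assay gives "not determined" (no result reported), so it adds nothing to the comparison. Going by the values given here, compound 3 therefore stands level with the one measured neighbour, with no ordering between them.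

Compound 4 `O=C(N1CCCC1)N(Cc1ccccc1-c1ccccc1)[C@H]1CCNC1` differs from compound 3 in one place: pyrrolidin-1-yl in place of dimethylamino on a carbonyl carbon. Among the compounds with values here, no measured step bears directly on this change; the only step available, the exchange of isopropylsulfonyl for dimethylcarbamoyl from compound 1 to compound 3, was within the scatter, and it touches a different part of the molecule. The dialkylamino end of the urea is tied into a five-membered ring; nothing in the two numbers shown points to a shift in either direction, so the expected step of a 1.2-fold lower number from compound 3 to compound 4 (0.07 log units; within the scatter) is expected to stay within the scatter. For compound 4 in this assay the estimate is 2500 nM, with a range from 900 nM to 7000 nM.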

Compound 4, inhibition constant: 4190 nM
Compound 4: the middle estimate sits 1.7-fold (0.22 log units) below what was measured; the range from low to high includes it.
By their numbers in this assay, from the lowest: compounds 1, 3 and 4 (each within the scatter of the next).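

In this assay, for the compounds shown here, the change from dimethylamino to pyrrolidin-1-yl on a carbonyl carbon gives a 1.4-fold higher number from compound 3 to compound 4 (0.15 log units; within the scatter) and so shows that this end of the urea, which no earlier step touched, accepts a group of 5 heavy atoms with one five-membered non-aromatic ring in place of 3 heavy atoms and no ring, with no step beyond the scatter. The larger exchange on the amine nitrogen, (pyrrolidin-1-yl)carbonyl in place of isopropylsulfonyl, gives a 1.6-fold higher number from compound 1 to compound 4 (0.19 log units; within the scatter) and also stays within the scatter, so compound 1, compound 3 and compound 4 stand level, with no ordering among them. No measurement offers an explanation for these numbers.

The compounds shown leave open whether any group on this carbonyl carbon can move the number beyond the scatter in either direction. A piperidin-1-yl or morpholin-4-yl group, an unsubstituted amino group or a longer chain on the nitrogen of the urea would show whether this position responds at all in this assay or whether the series stays level.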